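One Ring Swap at the Carbonyl End of Compound 1

The compounds below may be only part of what the source reports. "The series", "measured", "known", "first", "only" and "open" are said of these compounds alone.

Of the compounds shown here, three have been measured in a functional assay on MCF7 cells (Homo sapiens) for cytotoxicity, read by MTT assay, with a stated time of 72 h; a lower number here means a stronger inhibitor, a higher number a weaker inhibitor. Compound 1 `COc1cc2ncnc(NNC(=S)NC(=O)c3ccccc3C)c2cc1OC` gives 19300 nM. Compound 2 `O=C(NC(=S)NNc1ncnc2ccccc12)c1ccc(C(F)(F)F)cc1` gives 8050 nM, and compound 3 `Cc1ccc(C(=O)NC(=S)NNc2ncnc3ccccc23)cc1` gives 7820 nM. Compound 1 therefore stands highest of the three numbers, which makes it the weakest inhibitor of the set; its nearest neighbour is compound 2, and its gaps to both other compounds lie beyond the scatter. Within the data shown here, the only measured step between compounds that differ in one place is a 1.0-fold lower number from compound 2 to compound 3 (0.01 log units; within the scatter), a change that left the number essentially where it was.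

Compound 4 `COc1cc2ncnc(NNC(=S)NC(=O)c3cccc(Cl)c3)c2cc1OC` is the next compound to be tested. It differs from compound 1 in one place: 3-chlorophenyl in place of 2-methylphenyl on a carbonyl carbon. Among the measured compounds shown here, no measured pair shows this exact exchange. For the measured compounds named here, the nearest precedent is the step between compound 2 and compound 3, where swapping one substituent for another on the same kind of aromatic ring changed nothing beyond the scatter. On that basis, a change confined to this outer ring is expected to move the number little, if at all, with no clear direction. Compound 4 is therefore estimated at 15000 nM, within a range of 6000 nM to 38000 nM, which means an expected step of a 1.3-fold lower number from compound 1 to compound 4 (0.11 log units; within the scatter).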

Compound 4, half-maximal inhibitory concentration: 11500 nM
Compound 4: the middle estimate sits 1.3-fold (0.12 log units) above what was measured, within the range that was stated.
By their numbers in this assay, from the lowest: compounds 3, 2, 4 and 1 (each within the scatter of the next, the first and the last beyond it).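

With the core of compound 1 held fixed, putting 3-chlorophenyl in place of 2-methylphenyl on the carbonyl carbon gives, in this assay, a 1.7-fold lower number from compound 1 to compound 4 (0.22 log units; within the scatter), so this exchange of two rings of equal heavy-atom count does not move the number beyond the usual scatter. It is the only step shown on this core, and it joins a 1.0-fold lower number from compound 2 to compound 3 (0.01 log units; within the scatter) as a second single-place change on the outer ring that stays within the scatter, with no pair shown going against it, although that earlier pair carries a different core. No measurement is available here to explain why the number stays within the scatter.

From the compounds shown here alone, this swap changes both which group the ring carries and where that group sits, so the share of each in the step remains open. Going by these compounds, it also remains open whether the number would stay as steady with an amine or a carboxylic acid on this ring, or with a longer chain on the carbonyl carbon in place of the ring.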